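Adding a Nitrile to the Pendant Phenyl

This account rests on a few compounds, and the source may have more. Where it says the series, first, only, none or still open, it means among the compounds named here.

Compound 1, `Cn1cncc1C(O)(c1ccc(C#N)cc1)c1cc2cc([N+](=O)[O-])cc(-c3ccccc3)c2o1`: 1480 nM
Compound 2, `Cn1cncc1C(O)(c1ccc(C#N)cc1)c1cc2cc(C#N)cc(-c3ccccc3)c2o1`: 14.5 nM
Compound 3, `Cn1cncc1C(O)(c1ccc(Br)cc1)c1cc2cc([N+](=O)[O-])cc(-c3ccccc3)c2o1`: 1480 nM

In a functional assay on QG-56 cells (Homo sapiens) for antiproliferative activity (a lower number here means a stronger inhibitor, a higher number a weaker inhibitor), compound 1 stands level with compound 3, and together these two give the highest numbers of the three. Compound 2 sits far lower: a 100-fold lower number from compound 1 to compound 2 (2.01 log units; beyond the scatter). Compound 4, `Cn1cncc1C(O)(c1ccc(C#N)cc1)c1cc2cc([N+](=O)[O-])cc(-c3ccc(C#N)cc3)c2o1`, differs from compound 1 in one place: cyano in place of hydrogen on an aromatic carbon. Neither measured step concerns this phenyl. The large step of a 100-fold lower number from compound 1 to compound 2 (2.01 log units; beyond the scatter) swaps a different group on the shared core, and no change at the digits printed from compound 1 to compound 3 (within the scatter) changes a group elsewhere in the molecule. Among the compounds with values here, no measured step therefore bears directly on this change, and the expected step is one within the scatter, a 1.2-fold lower number from compound 1 to compound 4 (0.09 log units; within the scatter). Compound 4 is estimated at 1200 nM, within a range from 300 nM to 5000 nM.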

Compound 4, half-maximal inhibitory concentration: 32.6 nM
Estimate against measurement, compound 4: 37-fold (1.57 log units) above; the measured number lies below the stated range.
By their numbers in this assay, from the lowest: compound 2; then compound 4; then compounds 1 and 3 (each within the scatter of the next).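

In this assay, the change from phenyl to 4-cyanophenyl gives a 45-fold lower number from compound 1 to compound 4 (1.66 log units; beyond the scatter) with the nitro group left in place. The earlier compounds shown here showed a large step only at a different group on the shared core, so this phenyl is a second place where one small change moves the number strongly. Nothing measured here explains how the nitrile does this.

The compounds shown leave open whether an amine or a methoxy group at this same place would give a similar step. They also leave open whether the 4-cyanophenyl change would lower the number further on compound 2, which already carries cyano instead of nitro.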